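Chain extension from compound 2 to compound 3

This account rests on a few compounds, and the source may have more. Where it says the series, first, only, none or still open, it means among the compounds named here.

Compound 1 `CCOc1cc(OC)c(Br)cc1C(C)=O`: 57700000 nM
Compound 2 `CCCCCCCCOc1cc(OC)c(Br)cc1C(C)=O`: 38100000 nM

Both values come from a functional assay, with a stated time of 10 min; on this read-out lower numbers stand for stronger inhibition and higher numbers for weaker inhibition. Compound 2 stands within the scatter of compound 1, so the two cannot be ranked. Among the measured compounds shown here, the only measured step, a 1.5-fold lower number from compound 1 to compound 2 (0.18 log units; within the scatter), comes with hexyl in place of hydrogen on a saturated chain carbon, two bonds along the chain from an oxygen on an aromatic ring.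

Compound 3 `CCCCCCCCCCCCCCCCOc1cc(OC)c(Br)cc1C(C)=O` has not yet been measured. Its change is octyl in place of hydrogen on a saturated chain carbon, eight bonds along the chain from an oxygen on an aromatic ring, with octyl in place of hydrogen on a saturated chain carbon, eight bonds along the chain from an oxygen on an aromatic ring. For the measured compounds named here, the single earlier step, a 1.5-fold lower number from compound 1 to compound 2 (0.18 log units; within the scatter), offers no firm trend, so no step beyond the scatter is expected in this assay, and no direction is favoured. The estimated change is a 1.1-fold lower number from compound 2 to compound 3 (0.04 log units; within the scatter). Compound 3 is expected at 35000000 nM, with an estimated range of 12000000 nM to 85000000 nM.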

Compound 3, half-maximal inhibitory concentration: 100000 nM
Beside the measured number, compound 3's estimate is 350-fold (2.54 log units) above it, outside the stated range (below it).
By their numbers in this assay, from the lowest: compound 3; then compounds 2 and 1 (each within the scatter of the next).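

The chain position does respond to length in this assay, and the response is not even: the step to the hexadecyl-length chain is large (a 380-fold lower number from compound 2 to compound 3 (2.58 log units; beyond the scatter)), while the earlier hexyl change stayed within the scatter (a 1.5-fold lower number from compound 1 to compound 2 (0.18 log units; within the scatter)). Octyl in place of hydrogen, eight bonds along the chain from an oxygen on an aromatic ring, therefore gives the first step beyond the scatter in the series, something compounds 1 and 2 gave no sign of. Nothing available explains why this chain extension has so much more effect than the earlier one.

Compounds 1, 2 and 3 leave open whether the response to chain length rises gradually or sharply between compound 2 and compound 3. They also leave open whether a longer chain, or a chain of this length ending in an amine or a carboxylic acid, would keep the stronger inhibition seen with compound 3.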